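Thiophene for Pyridine at the Benzylic Ether Position

A few compounds are considered here, and "the series" means these few. Any claim that something is new, unique, unknown or untested is made for them only; others in the source may bear on it.

Measured compounds:
compound 1, `Cc1nc2c(OCc3ccccc3)cccn2c1N`: 96%
compound 2, `Cc1nc2c(OCc3ccccn3)cccn2c1N`: 15%

In a functional assay on the whole organism with Canis familiaris (Canis lupus familiaris) as the target, at a dose of 8 mg/kg by the oral route (on this read-out higher numbers stand for a stronger effect at the one dose given and lower numbers for a weaker effect), compound 1 gives 96%, while compound 2 gives 15%. For the measured compounds named here, the single step between them, a number 81 percentage points lower from compound 1 to compound 2 (beyond the scatter), is large and beyond the scatter. Going by the values given here, compound 2 thus stands lowest of the two numbers, with compound 1 its only neighbour, a number far higher.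

Compound 3, `Cc1nc2c(OCc3cccs3)cccn2c1N`, has not yet been measured in this assay. It differs from compound 2 as follows: thiophen-2-yl in place of pyridin-2-yl on a saturated chain carbon bound to an oxygen on an aromatic ring. Among the compounds with values here, the one measured step bears directly on this position and was large, so the read-out at this place is clearly sensitive to which aromatic ring stands there. Since the ring entering is neither of the two already measured, the direction is uncertain, but compound 3 is expected to move back up rather than stay at the low end; the step of a number 50 percentage points higher from compound 2 to compound 3 (beyond the scatter) is expected to be sizeable. For compound 3 an inhibition of 65% is estimated, in a range of 25% to 95%.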

Compound 3, a percentage reported as inhibition, in the whole organism at one dose (the size of the read-out at that dose, not a potency): 86%
Beside the measured number, compound 3's estimate is 21 percentage points below it; low and high end bracket the measured number.
By their numbers in this assay, from the lowest: compound 2; then compounds 3 and 1 (each within the scatter of the next).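

In this assay, thiophen-2-yl in place of pyridin-2-yl gives a number 71 percentage points higher from compound 2 to compound 3 (beyond the scatter), so a hetero atom in the ring at this place does not by itself bring the low read-out of compound 2. Thiophen-2-yl in place of phenyl gives a number 10 percentage points lower from compound 1 to compound 3 (within the scatter), so this assay does not separate these two rings, and among the three compounds only the pyridin-2-yl one stands apart. Nothing in the available evidence explains this difference.

From the compounds shown here alone, whether the low number is particular to pyridin-2-yl or would also appear with furan-2-yl or pyridin-3-yl remains open. Also open, going by these compounds, is how the read-out would respond to a longer chain in place of the saturated chain carbon bound to the oxygen, and how these compounds compare at other doses.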